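This account rests on a few compounds, and the source may have more. Where it says the series, first, only, none or still open, it means among the compounds named here.

Compound 1 `COC1=C(C)C(=O)/C(=C(O)/C=C/c2ccccc2OC)C(=O)C1(C)C`: 1.7 ug/mL
Compound 2 `COC1=C(C)C(=O)/C(=C(O)/C=C/c2ccc(F)cc2)C(=O)C1(C)C`: 2 ug/mL
Compound 3 `COC1=C(C)C(=O)/C(=C(O)/C=C/c2c(C)cccc2C)C(=O)C1(C)C`: 3 ug/mL

These three compounds share one core and were tested in a functional assay on HUVEC cells (Homo sapiens) for cytotoxicity; a higher number here means that more compound is needed for the effect, a lower number that less compound is needed. They differ only in the aromatic group on the chain. In this assay, compound 3 gives 3 ug/mL, which cannot be told apart from the other two values. The measured comparisons with compound 3 are a 1.8-fold higher number from compound 1 to compound 3 (0.25 log units; within the scatter) and a 1.5-fold higher number from compound 2 to compound 3 (0.18 log units; within the scatter), and both lie within the scatter.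

The next structure is compound 4 `COC1=C(C)C(=O)/C(=C(O)/C=C/c2nccs2)C(=O)C1(C)C`, and the change leading to it is 1,3-thiazol-2-yl in place of 2,6-dimethylphenyl on a double-bonded chain carbon bound to a double-bonded chain carbon. A carbon-only six-membered ring therefore gives way to a five-membered aromatic ring that holds two hetero atoms.

Among the compounds with values here, all the measured steps bear on this swap, since each replaces one group at this same place. Besides the two above, there is a 1.2-fold higher number from compound 1 to compound 2 (0.07 log units; within the scatter), also within the scatter. So far, then, changing this group has produced no clear shift in this assay. However, none of the measured compounds carries a five-membered ring, so the data do not directly cover thiazole, and the range must stay fairly wide.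

The expected change is a 1.3-fold lower number from compound 3 to compound 4 (0.12 log units; within the scatter), which means no step beyond the scatter is anticipated. The estimate for compound 4 is 2.3 ug/mL, with an expected range from 1 ug/mL to 5 ug/mL.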

Compound 4, concentration for half-maximal effect: 1.6 ug/mL
For compound 4 the middle estimate is 1.4-fold (0.16 log units) above the measured one; low and high end bracket the measured number.
By their numbers in this assay, from the lowest: compounds 4, 1, 2 and 3 (each within the scatter of the next).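

Compound 4 brings the first five-membered aromatic ring to this place, and its 1,3-thiazol-2-yl group holds nitrogen and sulfur where the earlier groups had carbon-only aromatic rings, yet in this assay the three new comparisons show a 1.9-fold lower number from compound 3 to compound 4 (0.27 log units; within the scatter) and a 1.3-fold lower number from compound 2 to compound 4 (0.10 log units; within the scatter) and also a 1.1-fold lower number from compound 1 to compound 4 (0.03 log units; within the scatter) as the last of them. The position on the double-bonded chain carbon therefore accepts a smaller ring of a different size and make-up, with hydrogen-bond acceptors that 2,6-dimethylphenyl lacks, without any shift beyond the scatter, and none of the four compounds goes against this. No measurement available here accounts for this flat result.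

As far as these compounds go, all four compounds carry an aromatic ring at this place, so it remains open whether the number would hold with a non-aromatic group there, such as an amine, a carboxylic acid or a longer alkyl chain. With every step inside the scatter, these compounds also leave open which groups at this place, if any, would move the number clearly in either direction.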